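The source may hold more compounds than are shown below. What is called first, only, known or untested is meant among the compounds shown, and "the series" means these compounds.

Compound 1 `Cc1ccc(-c2cc(N)n(-c3ccc(Br)cc3)n2)cc1` and compound 2 `Nc1cc(-c2ccc(Cl)cc2)nn1-c1ccc(Br)cc1` share one core, while compound 3 `Cc1ccc(-c2nn(-c3ccc(Br)cc3)c(/N=C/N(C)C)c2C=O)cc1` and compound 4 `CN(C)/C=N/c1c(C=O)c(-c2ccc(Cl)cc2)nn1-c1ccc(Br)cc1` share another; how the two cores differ is not broken down here. In a functional assay on Jurkat cells (Homo sapiens) for inhibition, read by MTT assay, with a stated time of 72 h (on this read-out lower numbers stand for stronger inhibition of growth and higher numbers for weaker inhibition of growth), compound 1 gives 45000 nM and compound 2 gives 61300 nM. Compound 3 gives 6700 nM in this assay, the lowest of the three measured numbers. Compound 4 differs from compound 3 by chloro in place of methyl on an aromatic carbon, the same change as chloro in place of methyl on an aromatic carbon, and this change appears twice among these compounds. Because that earlier change made a 1.4-fold higher number from compound 1 to compound 2 (0.13 log units; within the scatter), the step expected here is a 1.3-fold higher number from compound 3 to compound 4 (0.10 log units; within the scatter). Compound 4 is therefore estimated at 8500 nM in this assay, with an expected range from 4000 nM to 18000 nM.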

Compound 4, concentration for 50% growth inhibition: 38900 nM
The estimate for compound 4 lay 4.6-fold (0.66 log units) below the measured number; the measured number lies above the stated range.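

In this assay, chloro in place of methyl on an aromatic carbon gives a 5.8-fold higher number from compound 3 to compound 4 (0.76 log units; beyond the scatter), so this change does not carry over at the same size from one core to the other: the same change on two cores in this assay, a 1.4-fold higher number (0.13 log units; within the scatter) from compound 1 to compound 2 and a 5.8-fold higher number (0.76 log units; beyond the scatter) from compound 3 to compound 4, 4.3-fold (0.63 log units) apart, beyond the scatter of two such steps

This shows that, among these four compounds, the size of the 4-methylphenyl to 4-chlorophenyl step depends on the core. It rests on a single pair per core, however, and it does not show which part of the difference between the cores goes with the gap, or how the change would behave on any further core.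

As far as these compounds go, it remains open whether a fluoro, a methoxy group or an amine at this place would follow the smaller step or the larger one on either core.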